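This account rests on a few compounds, and the source may have more. Where it says the series, first, only, none or still open, it means among the compounds named here.

Three compounds of the series carry numbers in a functional assay on A549 cells (Homo sapiens) for antiproliferative activity, read by CCK-8 assay, with a stated time of 72 h; on this read-out lower numbers stand for stronger inhibition and higher numbers for weaker inhibition. Compound 1 `O=C(Nc1cccc(-c2oc3cc(-c4ccc(F)cc4)ccc3c(=O)c2O)c1)c1ccc(C(F)(F)F)cc1` gives 19400 nM, compound 2 `Cc1cccc(C(=O)Nc2cccc(-c3oc4cc(-c5ccc(F)cc5)ccc4c(=O)c3O)c2)c1` gives 16500 nM, and compound 3 `O=C(Nc1cccc(-c2oc3cc(-c4ccc(F)cc4)ccc3c(=O)c2O)c1)c1cc(F)cc(F)c1` gives 7620 nM, so compound 3 holds the lowest number of the three. Exchanging the aryl on the carbonyl carbon produced a 2.5-fold lower number from compound 1 to compound 3 (0.41 log units; beyond the scatter) and a 2.2-fold lower number from compound 2 to compound 3 (0.34 log units; beyond the scatter), whereas a 1.2-fold lower number from compound 1 to compound 2 (0.07 log units; within the scatter). Compound 4 `O=C(Nc1cccc(-c2oc3cc(-c4ccc(F)cc4)ccc3c(=O)c2O)c1)c1ccc([N+](=O)[O-])cc1` differs from compound 3 in that (4-nitrophenyl in place of 3,5-difluorophenyl on a carbonyl carbon). All three measured steps concern this same place and were modest at most, so for compound 4 a move back toward the numbers of compound 1 and compound 2 is expected, a 1.7-fold higher number from compound 3 to compound 4 (0.23 log units; within the scatter) in this assay. Compound 4 is therefore estimated at 13000 nM, within a range from 5000 nM to 35000 nM.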

Compound 4, half-maximal inhibitory concentration: 2440 nM
Compound 4: middle estimate off by 5.3-fold (0.73 log units), on the high side; measured number below the stated range.
By their numbers in this assay, from the lowest: compound 4; then compound 3; then compounds 2 and 1 (each within the scatter of the next).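

In this assay, going by these compounds alone, this position on the carbonyl carbon spans a wider range than the earlier compounds showed, with a 3.1-fold lower number from compound 3 to compound 4 (0.49 log units; beyond the scatter) and a 6.8-fold lower number from compound 2 to compound 4 (0.83 log units; beyond the scatter). The exchange of trifluoromethyl for nitro on an aromatic carbon gives the widest step, an 8.0-fold lower number from compound 1 to compound 4 (0.90 log units; beyond the scatter), so this one group exchange on the aryl outweighs every earlier change at this position. No measured property on hand accounts for these steps.

On these data alone, it remains open whether a nitrile or an amine in place of the nitro group would keep the number this low. Also open, as far as these compounds go, is whether the same order of compounds holds in other cell lines.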